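The source may report more compounds than this note shows. Statements on the series, on what has been measured and on what is new or still open speak of the compounds shown alone.

Measured so far:
Compound 1, `CS(=O)(=O)N1CC2(CC2)C[C@H](C(=O)NO)[C@H]1C(=O)N1C=CC(c2ccccc2)CC1`: 93 nM
Compound 2, `Cc1cccc(C2=CCN(C(=O)[C@H]3NCC4(CC4)C[C@@H]3C(=O)NO)CC2)c1`: 42 nM

Both numbers come from an assay on BT-474 cells for inhibition of disintegrin and metalloproteinase domain-containing protein 10 (Homo sapiens); a higher number here means a weaker inhibitor, a lower number a stronger inhibitor. Of the two, compound 2 has the lower number, and its gap to compound 1 lies beyond the usual scatter of repeated measurements, so compound 2 is the stronger inhibitor of the pair. The next compound, compound 3, `COc1cccc(C2=CCN(C(=O)[C@H]3NCC4(CC4)C[C@@H]3C(=O)NO)CC2)c1`, keeps the whole core of compound 2 and changes a single group: methoxy in place of methyl on an aromatic carbon. Among the measured compounds shown here, no pair of measured compounds shows this exchange, so there is no measured step to lean on. With nothing to point either way, the expected step is small, a 1.2-fold higher number from compound 2 to compound 3 (0.08 log units; within the scatter), and most likely not beyond the scatter in either direction. On that basis compound 3 is expected to give about 50 nM in this assay. The estimate for compound 3 is expected to fall between 20 nM and 130 nM.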

Compound 3, half-maximal inhibitory concentration: 194 nM
The estimate for compound 3 lay 3.9-fold (0.59 log units) below the measured number, and the stated range ends below it.
By their numbers in this assay, from the lowest: compound 2; then compound 1; then compound 3.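

In this assay, this aromatic carbon, meta to a large group, proves sensitive to what it carries: methoxy in place of methyl gives a 4.6-fold higher number from compound 2 to compound 3 (0.66 log units; beyond the scatter) and is therefore no neutral exchange here. The change from 3-methylphenyl to 3-methoxyphenyl adds only one oxygen atom and one hydrogen-bond acceptor, yet it moves the number beyond the scatter, something compound 1 and compound 2 could not show, as they differ in more than one place. Nothing available bears on the reason for this rise.

From the compounds shown here alone, it remains open whether the oxygen itself or simply the longer group goes with the weaker number; an ethyl, a hydroxyl or a plain hydrogen at this carbon would help separate the two. Going by these compounds, whether the same exchange behaves alike on the core of compound 1 is also open.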